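Swapping a hydrocarbon group for a vinyloxy group

This account rests on a few compounds, and the source may have more. Where it says the series, first, only, none or still open, it means among the compounds named here.

Compound 1, `CC(Oc1ccccc1Br)C1=NCCN1`, gives 316 nM in a functional assay on CHO cells for agonist activity at Alpha-2B adrenergic receptor (Homo sapiens); a lower number here means that less compound is needed, a higher number that more compound is needed for the effect.
Compound 2, `CCc1ccccc1OC(C)C1=NCCN1`, gives 10000 nM in this assay.
Compound 3, `C=C(C)c1ccccc1OC(C)C1=NCCN1`, gives 1580 nM in this assay.

Among these three numbers, compound 3 stands second highest: its nearest neighbour is compound 1, reached by the step of a 5.0-fold higher number from compound 1 to compound 3 (0.70 log units; beyond the scatter), and the furthest is compound 2, reached by the step of a 6.3-fold lower number from compound 2 to compound 3 (0.80 log units; beyond the scatter). Both steps lie beyond the scatter, so what sits at this one position on the ring clearly matters.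

The next compound, compound 4, `C=COc1ccccc1OC(C)C1=NCCN1`, carries the change (vinyloxy in place of 1-methylethenyl on an aromatic carbon). The group sits on an aromatic carbon of a six-membered aromatic ring of carbon only, ortho to a group of 8 heavy atoms. For the measured compounds named here, the only steps that bear on it are the two just named, which change the same position. Going by the values given here, none of them, however, puts an oxygen-linked group there, so no measured step speaks directly to the direction. The entering group keeps the same count of heavy atoms and the same single double bond outside aromatic rings, and adds one acceptor.

With this in mind, the step of a 1.6-fold lower number from compound 3 to compound 4 (0.20 log units; within the scatter) is expected to be small. Compound 4 is estimated at 1000 nM, with a range from 300 nM to 3500 nM.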

Compound 4, half-maximal effective concentration: 3160 nM
The estimate for compound 4 lay 3.2-fold (0.50 log units) below the measured number, within the range that was stated.
By their numbers in this assay, from the lowest: compound 1; then compounds 3 and 4 (each within the scatter of the next); then compound 2.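

In this assay, the step from 1-methylethenyl to vinyloxy (a 2.0-fold higher number from compound 3 to compound 4 (0.30 log units; within the scatter)) shows that this swap, which adds a hydrogen-bond acceptor, gives two compounds that cannot be told apart at this place on the aromatic ring. Measured against the other groups, vinyloxy gives a modest gain over ethyl (a 3.2-fold lower number from compound 2 to compound 4 (0.50 log units; beyond the scatter)) but falls well short of bromo (a 10-fold higher number from compound 1 to compound 4 (1.00 log units; beyond the scatter)), so compound 1 keeps the lowest number of the four, with its steps to all three others lying beyond the scatter. Nothing measured here accounts for these differences between the groups.

From the compounds shown here alone, what chloro, methoxy or an amino group would give at this place remains open, and so does whether the low number of compound 1 belongs to bromo alone. Also open, going by these compounds, is whether the close match between vinyloxy and 1-methylethenyl would extend to a saturated oxygen-linked group such as ethoxy, which would pair directly with the ethyl group of compound 2.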